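Chloro to Cyano: What to Expect for Compound 3

A few compounds are considered here, and "the series" means these few. Any claim that something is new, unique, unknown or untested is made for them only; others in the source may bear on it.

Compound 1 `COC(=O)Nc1cc(-c2cnc(OC[C@@](C)(N)CC(C)C)c(Cl)c2)ccn1`: 0.4 nM
Compound 2 `COC(=O)Nc1cc(-c2ccc(OC[C@@](C)(N)CC(C)C)c(Cl)n2)ccn1`: 0.5 nM

In an assay on isolated protein for inhibition of AP2-associated protein kinase 1 (Homo sapiens), with a stated time of 3 h, in the presence of a further agent that is not named here (on this read-out higher numbers stand for weaker inhibition and lower numbers for stronger inhibition), compound 1 holds the lower of the two numbers, and compound 2 gives 0.5 nM, a gap within the usual scatter, so the two are not told apart. Compound 3 `COC(=O)Nc1cc(-c2cnc(OC[C@@](C)(N)CC(C)C)c(C#N)c2)ccn1` is not yet measured. It differs from compound 1 by cyano in place of chloro on an aromatic carbon. Going by the values given here, no measured pair shows this change, so its size is unknown; a step no larger than the scatter is expected, if anything toward a slightly higher number. Compound 3 is therefore expected to give 0.6 nM, in the range 0.2 nM to 2 nM. The expected step is a 1.5-fold higher number from compound 1 to compound 3 (0.18 log units; within the scatter).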

Compound 3, half-maximal inhibitory concentration: 1 nM
Compound 3: the middle estimate sits 1.7-fold (0.22 log units) below what was measured; the measured number falls inside the stated range.
By their numbers in this assay, from the lowest: compounds 1, 2 and 3 (each within the scatter of the next, the first and the last beyond it).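

In this assay, placing cyano instead of chloro on this aromatic carbon, ortho to the (2-amino-2,4-dimethylpentyl)oxy group, gives a 2.5-fold higher number from compound 1 to compound 3 (0.40 log units; beyond the scatter) and so a modest loss of inhibition. This shows that the position responds to the group it carries, yet compound 3 still gives 1 nM and so keeps strong inhibition. No measurement shown here explains the step. Still open, on these data alone, is how fluoro, methyl or methoxy would compare with chloro at this position. Also open, as far as these compounds go, is whether the same swap on compound 2 would give a similar step.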